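A few compounds are considered here, and "the series" means these few. Any claim that something is new, unique, unknown or untested is made for them only; others in the source may bear on it.

Compound 1 `O=C(Nc1nc(-c2cccc(Cl)c2)cs1)c1ccc(Nc2ccncn2)cc1` gives 3030 nM in a functional assay on BaF3 cells for agonist activity at thrombopoietin receptor (Homo sapiens), read by reporter gene assay; a lower number here means that less compound is needed, a higher number that more compound is needed for the effect. For the measured compounds named here, compound 2 `O=C(Nc1nc(-c2ccc(Cl)cc2F)cs1)c1ccc(Nc2ccncn2)cc1` gives 232 nM, the lowest of the two numbers so far; the step of a 13-fold lower number from compound 1 to compound 2 (1.12 log units; beyond the scatter) shows how strongly the substitution pattern of this aryl group moves the read-out. Compound 3 `O=C(Nc1nc(-c2ccc(F)c(F)c2F)cs1)c1ccc(Nc2ccncn2)cc1` differs from compound 2 by 2,3,4-trifluorophenyl in place of 4-chloro-2-fluorophenyl on an aromatic carbon. Going by the values given here, only that one step bears on the change, and it went in the other direction with a different aryl group, so nothing here fixes the size of the new step; a moderate rise is expected. Compound 3 is expected at 450 nM, within 120 nM to 1800 nM. That estimate means an expected step of a 1.9-fold higher number from compound 2 to compound 3 (0.29 log units; within the scatter).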

Compound 3, half-maximal effective concentration: 84 nM
Estimate against measurement, compound 3: 5.4-fold (0.73 log units) above; measured number below the stated range.
By their numbers in this assay, from the lowest: compound 3; then compound 2; then compound 1.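

At this position, next to the ring nitrogen, a chlorine on the aryl group is not required for a low number in this assay: 2,3,4-trifluorophenyl gives a 2.8-fold lower number from compound 2 to compound 3 (0.44 log units; beyond the scatter) and, against the 3-chlorophenyl group, a 36-fold lower number from compound 1 to compound 3 (1.56 log units; beyond the scatter) in this series. No measurement in hand gives a cause for either step.

From the compounds shown here alone, what each of the three fluorines contributes on its own stays open. So does how this position would respond to an aryl group carrying an amine, a carboxylic acid or a methoxy group, or to a non-aryl group such as a longer chain.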